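Aryl substitution on the shared core: amino to trifluoroacetyl

The source may report more compounds than this note shows. Statements on the series, on what has been measured and on what is new or still open speak of the compounds shown alone.

Measured compounds:
compound 1 `Nc1ccccc1-c1cnc(C(=O)CCCCCCc2ccccc2)o1` 750 nM
compound 2 `N#Cc1ccccc1-c1cnc(C(=O)CCCCCCc2ccccc2)o1` 130 nM
compound 3 `Nc1cccc(-c2cnc(C(=O)CCCCCCc3ccccc3)o2)c1` 19 nM

In an assay (Rattus norvegicus) for inhibition of Fatty-acid amide hydrolase 1 (Homo sapiens) (a higher number here means a weaker inhibitor, a lower number a stronger inhibitor), compound 3 gives the lowest number of the three; the nearest is compound 2 at 130 nM, the furthest compound 1 at 750 nM. Compound 4 `O=C(CCCCCCc1ccccc1)c1ncc(-c2cccc(C(=O)C(F)(F)F)c2)o1` differs from compound 3 by (trifluoromethyl)carbonyl in place of amino on an aromatic carbon. Within the data shown here, two measured steps bear on this. Replacing the amino group with a non-donor acceptor gave a 5.8-fold lower number from compound 1 to compound 2 (0.76 log units; beyond the scatter), and moving the amino group to the position meta to the large group gave a 39-fold lower number from compound 1 to compound 3 (1.60 log units; beyond the scatter). Compound 4 keeps the position of compound 3 and removes the donor, so a modest further lowering in this assay is expected, a 3.2-fold lower number from compound 3 to compound 4 (0.50 log units; beyond the scatter). The estimate for compound 4 is 6 nM, with a range of 1.5 nM to 25 nM.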

Compound 4, inhibition constant: 16 nM
Compound 4: the middle estimate sits 2.7-fold (0.43 log units) below what was measured; the measured number falls inside the stated range.
By their numbers in this assay, from the lowest: compounds 4 and 3 (each within the scatter of the next); then compound 2; then compound 1.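

In this assay, (trifluoromethyl)carbonyl in place of amino on this aromatic carbon, meta to a large group, gives a 1.2-fold lower number from compound 3 to compound 4 (0.07 log units; within the scatter), so this assay does not separate the two groups here. A hydrogen-bond donor on this carbon is therefore not required for a number at this level, and the larger group with its 6 heavy atoms is accepted at this position. No measurement shown here accounts for this result.

Going by these compounds, whether a carboxylic acid or a methyl ester on this carbon would stay level with compounds 3 and 4 remains open. Also open, on these data alone, is whether (trifluoromethyl)carbonyl would give a similar number at the position of the amino group in compound 1.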